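The source may report more compounds than this note shows. Statements on the series, on what has been measured and on what is new or still open speak of the compounds shown alone.

Compound 1 `COc1ncnc2c1c(-c1ccsc1)cn2[C@@H]1O[C@H](CO)[C@@H](O)[C@H]1O` serves as the reference point. In a functional assay on HCT-116 cells (Homo sapiens), read by MTT assay, with a stated time of 72 h (a lower number here means a stronger inhibitor, a higher number a weaker inhibitor), compound 1 gives 140 nM. Compound 2 `CNc1ncnc2c1c(-c1ccsc1)cn2[C@@H]1O[C@H](CO)[C@@H](O)[C@H]1O` differs from it by methylamino in place of methoxy on an aromatic carbon. In this assay compound 2 reaches only a limit of the assay, > 20000 nM, so the limit of > 20000 nM in this assay, at which 1 of the 3 values shown sits, applies and the change from compound 1 to compound 2 is recorded as an at least 140-fold higher number from compound 1 to compound 2 (2.15 log units; beyond the scatter). Compound 3 `COc1ncnc2c1c(-c1cc3ccccc3o1)cn2[C@@H]1O[C@H](CO)[C@@H](O)[C@H]1O` differs from compound 1 by 1-benzofuran-2-yl in place of thiophen-3-yl on an aromatic carbon. In this assay compound 3 gives 14500 nM, which is a 100-fold higher number from compound 1 to compound 3 (2.02 log units; beyond the scatter). Compound 4 `CNc1ncnc2c1c(-c1cc3ccccc3o1)cn2[C@@H]1O[C@H](CO)[C@@H](O)[C@H]1O` remains unmeasured; it differs from compound 3 by methylamino in place of methoxy on an aromatic carbon, the same change as that from compound 1 to compound 2, made on the core of compound 3 instead of the core of compound 1. Since the earlier step is an at least 140-fold higher number from compound 1 to compound 2 (2.15 log units; beyond the scatter) and compound 3 already sits at 14500 nM, compound 4 is expected to lose further potency, estimated as a 10-fold higher number from compound 3 to compound 4 (1.01 log units; beyond the scatter). In this assay compound 4 is therefore estimated at 150000 nM, between 25000 nM and 1000000 nM, most likely reported only as a limit.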

Compound 4, half-maximal inhibitory concentration: > 20000 nM
Compound 4 was reported as a limit (the forecaster's own chance of this, stated with the estimate: 85%); the middle value lies beyond the limit too.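

In this assay, methylamino in place of methoxy on the core of compound 3 is recorded as an at least 1.3-fold higher number from compound 3 to compound 4 (0.13 log units; that floor lies within the scatter), while the step from compound 2 to compound 4 cannot be read. Set beside the same change on the core of compound 1, this leaves the comparison unresolved, so the large loss on that core is neither confirmed nor contradicted on the core of compound 3: the same change on two cores in this assay, an at least 140-fold higher number (2.15 log units; beyond the scatter) from compound 1 to compound 2 and an at least 1.3-fold higher number (0.13 log units; that floor lies within the scatter) from compound 3 to compound 4; the limit leaves it open whether they differ. Compound 2 and compound 4 are both limits and not numbers, so neither core gives a measured size for this change: the limit of > 20000 nM in this assay, at which 2 of the 4 values shown sit.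

The compounds shown leave open how large the change really is on either core, and how far a benzofuran or thiophene substituent alters it. An ethoxy group, a plain amine or a dimethylamino group in the place held by methoxy, on both cores, would show whether the step belongs to methylamino alone.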